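Notes on a prostaglandin D2 receptor 2 binding series

The source may report more compounds than this note shows. Statements on the series, on what has been measured and on what is new or still open speak of the compounds shown alone.

Measured so far:
compound 1 `O=C(O)Cc1sc(C(c2ccccc2)c2ccccc2)nc1-c1ccc(C(F)(F)F)cc1`: in an in vitro assay on HEK385-7 cells for displacement of a labelled ligand from prostaglandin D2 receptor 2 (Homo sapiens) (a lower number here means a stronger inhibitor, a higher number a weaker inhibitor), compound 1 gives 1100 nM
compound 2 `NS(=O)(=O)c1cccc(-c2nc(C(c3ccc(F)cc3)c3ccc(F)cc3)sc2CC(=O)O)c1`: in this assay compound 2 gives 140 nM
compound 3 `O=C(O)Cc1sc(C(c2ccccc2)c2ccc(F)cc2)nc1-c1ccc(Cl)cc1`: in this assay compound 3 gives 17 nM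

Compound 2 holds the second highest of the three numbers. Its nearest neighbour is compound 1, whose number is higher by a gap beyond the scatter; compound 3 lies furthest, with a lower number, again beyond the scatter. Among the compounds with values here, no two measured compounds differ in one place only, so no single-point step is available.

Compound 4 `O=C(O)Cc1sc(C(c2ccc(F)cc2)c2ccc(F)cc2)nc1-c1ccnc(O)c1` is the next compound, derived from compound 2 by one change: 2-hydroxypyridin-4-yl in place of 3-sulfamoylphenyl on an aromatic carbon

Both groups carry one hydrogen-bond donor and two acceptors, so the step from compound 2 to compound 4 is expected to be small, a 1.4-fold higher number from compound 2 to compound 4 (0.15 log units; within the scatter), not clearly beyond the scatter in either direction. Compound 4 is estimated at 200 nM, within 60 nM to 700 nM.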

Compound 4, half-maximal inhibitory concentration: 68 nM
Beside the measured number, compound 4's estimate is 2.9-fold (0.47 log units) above it; measured number inside the range.
By their numbers in this assay, from the lowest: compound 3; then compound 4; then compound 2; then compound 1.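

Swapping 3-sulfamoylphenyl for 2-hydroxypyridin-4-yl on the aromatic carbon next to the ring nitrogen gives a 2.1-fold lower number from compound 2 to compound 4 (0.31 log units; beyond the scatter) in this assay and provides the first single-place comparison in the series. The step is modest but beyond the scatter, so the sulfamoyl group is not needed at this position to hold a number of this size. No measurement bears on why the number moves. Still open, on these data alone, is whether a 2-aminopyridin-4-yl or 2-methoxypyridin-4-yl group here would match compound 4, and whether the hydroxyl or the ring nitrogen accounts for the step.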